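A few compounds are considered here, and "the series" means these few. Any claim that something is new, unique, unknown or untested is made for them only; others in the source may bear on it.

Measured so far:
- compound 1, `O=C(O)/C(F)=C/c1ccc(O)c(O)c1`, gives -5.8% in a functional assay on the whole organism (strain CD1) for inhibition, with Mus musculus as the target, with stated times of 15 min and 20 min, at a dose of 10 mg/kg by the subcutaneous route; a lower number here means less inhibition, a higher number more inhibition at the dose given (going by the name of the read-out)
- compound 2, `N#C/C(=C\c1cc2ccccc2[nH]1)C(=O)O`, gives 25.8% in this assay
- compound 3, `CC(C)(C)OC(=O)/C(C#N)=C/c1cc2ccccc2[nH]1`, gives 51.3% in this assay

Compound 3 stands highest of the three values, with compound 2 nearest and compound 1 furthest, both lower by steps beyond the usual scatter of repeated measurements. Among the compounds with values here, the only step between measured compounds that differ in one place is a number 25.5 percentage points higher from compound 2 to compound 3 (beyond the scatter), a modest rise that belongs to the ester group itself.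

Compound 4, `N#C/C(=C\c1cc2ccccc2[nH]1)C(=O)OC1CCCCC1`, has not yet been measured in this assay. It differs from compound 3 in one place: cyclohexyl in place of tert-butyl on an oxygen next to a carbonyl group. Within the data shown here, no measured pair shows an exchange of one ester group for another, so no step directly bears on this change; the step from compound 2 to compound 3 only shows that an ester in this place is compatible with the higher value. Because of 51.3% for compound 3, compound 4 is expected to sit near that number, with a step of a number 3.3 percentage points lower from compound 3 to compound 4 (within the scatter), within the scatter. The estimate for compound 4 is therefore 48%, in a range from 22% to 74%.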

Compound 4, a percentage reported as inhibition, in the whole organism at one dose (the size of the read-out at that dose, not a potency): 83.6%
Estimate against measurement, compound 4: 35.6 percentage points below; measured number outside the range, above it.
By their numbers in this assay, from the lowest: compound 1; then compound 2; then compound 3; then compound 4.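

In this assay the choice of group on this ester oxygen still matters once an ester is in place: cyclohexyl in place of tert-butyl gives a number 32.3 percentage points higher from compound 3 to compound 4 (beyond the scatter) and this is a large change. Against the free acid, the exchange reads a number 57.8 percentage points higher from compound 2 to compound 4 (beyond the scatter) and so shows that the read-out depends on which group the ester carries, not only on an ester being there. Nothing available here gives a reason for this rise.

Cyclohexyl differs from tert-butyl both in carrying a ring and in its count of carbons, so these two compounds cannot say which of the two goes with the higher number. A cyclopentyl ring, a straight hexyl chain or a benzyl group on the same oxygen would help to separate them.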